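Replacing 4-(methylsulfonyl)phenyl with 3-ethylphenyl in compound 3

The source may report more compounds than this note shows. Statements on the series, on what has been measured and on what is new or still open speak of the compounds shown alone.

Compound 1 `Cc1nn(-c2ccccc2)c2nc(-c3ccc(F)cc3)c(C#N)c(-c3ccccc3O)c12` gives 6000 nM
Compound 2 `Cc1nn(-c2ccccc2)c2nc(-c3ccc([N+](=O)[O-])cc3)c(C#N)c(-c3ccccc3O)c12` gives 6000 nM
Compound 3 `Cc1nn(-c2ccccc2)c2nc(-c3ccc(S(C)(=O)=O)cc3)c(C#N)c(-c3ccccc3O)c12` gives 5000 nM

These values come from a physicochemical assay for solubility, read by spectrophotometry, in phosphate buffer, with a stated time of 18 h, at pH 7.4 (on this read-out lower numbers stand for lower solubility and higher numbers for higher solubility), and compound 3 is not separated from the other two compounds by more than the scatter. Compound 4 `CCc1cccc(-c2nc3c(c(C)nn3-c3ccccc3)c(-c3ccccc3O)c2C#N)c1` differs from compound 3 in one place: 3-ethylphenyl in place of 4-(methylsulfonyl)phenyl on an aromatic carbon and so 3-ethylphenyl stands in place of 4-(methylsulfonyl)phenyl on an aromatic carbon next to the ring nitrogen.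

Going by the values given here, three measured steps bear on this position: no change at the digits printed from compound 1 to compound 2 (within the scatter) and a 1.2-fold lower number from compound 1 to compound 3 (0.08 log units; within the scatter) and a 1.2-fold lower number from compound 2 to compound 3 (0.08 log units; within the scatter) and each stays small. Among the compounds with values here, none of them brings in an ethyl group, and the data hold no direct precedent for this exchange. Those small steps argue against a large move in this assay while a modest fall remains a judgement, since the whole group is exchanged here. The step expected is a 1.7-fold lower number from compound 3 to compound 4 (0.22 log units; within the scatter) at a rough estimate. The estimated value for compound 4 is 3000 nM within an expected range of 1000 nM to 7000 nM in this estimate.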

Compound 4, solubility: 11000 nM
For compound 4 the middle estimate is 3.7-fold (0.56 log units) below the measured one; measured number outside the range, above it.
By their numbers in this assay, from the lowest: compounds 3, 1, 2 and 4 (each within the scatter of the next, the first and the last beyond it).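

In this assay, going by these compounds alone, the exchange gives a 2.2-fold higher number from compound 3 to compound 4 (0.34 log units; beyond the scatter) and so yields the first step at this position that the earlier compounds did not supply, all their steps having stayed within the scatter. The separation holds against compound 3 alone, since the same kind of exchange gives a 1.8-fold higher number from compound 2 to compound 4 (0.26 log units; within the scatter) and a 1.8-fold higher number from compound 1 to compound 4 (0.26 log units; within the scatter) and neither of these lies beyond the scatter. Nothing at hand accounts for the step.

Compound 4 differs from compound 3 in both the substituent and its place on the phenyl ring, so the compounds shown do not separate these two changes. From the compounds shown here alone, how an amine, a carboxylic acid or a chain longer than ethyl on that phenyl ring would read in this assay also stays open.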